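Swapping an open ester chain for a morpholine amide

The compounds below may be only part of what the source reports. "The series", "measured", "known", "first", "only" and "open" are said of these compounds alone.

Of the compounds shown here, three sharing one core have been tested in an ADME assay on HeLa cells (Homo sapiens) for cytotoxicity, read by MTT assay; a higher number here means a weaker inhibitor, a lower number a stronger inhibitor. Compound 1 `COc1ccc(C[C@H]2COC(=O)[C@@H]2Cc2ccc(OCC(=O)Nc3ccccc3)c(OC)c2)cc1OC` reaches only the limit of the assay, >= 600000 nM, and no number is known for it. Compound 2 `COc1ccc(C[C@H]2COC(=O)[C@@H]2Cc2ccc(OCc3cn(-c4ccc(Br)cc4)nn3)c(OC)c2)cc1OC` gives 128000 nM, and compound 3 `CCN(CC)C(=O)CCC(=O)Oc1ccc(C[C@H]2C(=O)OC[C@@H]2Cc2ccc(OC)c(OC)c2)cc1OC` gives 213000 nM; these two numbers lie within the usual scatter of each other, so neither can be called the stronger. Going by the values given here, compound 3 thus stands with compound 2 as the only measured numbers, the rest being a limit. Two steps start from compound 1: an at least 4.6-fold lower number from compound 1 to compound 2 (0.67 log units; beyond the scatter) and an at least 2.8-fold lower number from compound 1 to compound 3 (0.44 log units; beyond the scatter), both lower bounds only because of the limit of >= 600000 nM in this assay, at which 1 of the 3 values shown sits.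

Compound 4 `COc1ccc(C[C@H]2COC(=O)[C@@H]2Cc2ccc(OCC(=O)N3CCOCC3)c(OC)c2)cc1OC` differs from compound 3 at the same position on the aromatic oxygen: a group of 9 heavy atoms (6 carbon, 1 nitrogen, 2 oxygen; one six-membered non-aromatic ring with 2 hetero atoms) in place of a group of 11 heavy atoms (8 carbon, 1 nitrogen, 2 oxygen; no ring), on an oxygen on an aromatic ring. Among the compounds with values here, no measured step exchanges one such side group for another between two compounds with real numbers; the steps from compound 1 only say that varied groups here land at or below its limit. With nothing pointing in a direction, a change of at most the scatter is expected, so the estimated step is a 1.1-fold lower number from compound 3 to compound 4 (0.03 log units; within the scatter). Compound 4 is therefore expected to give about 200000 nM, with a likely range from 80000 nM to 500000 nM.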

Compound 4, half-maximal inhibitory concentration: >= 600000 nM
Compound 4 gave a limit, no number; the forecaster's own chance of this, stated with the estimate: 20%; middle value at least 3.0-fold (0.47 log units) from the limit.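

Going by these compounds alone, the steps from compound 1 could show only that other groups on this oxygen on an aromatic ring bring the number down from a limit, whereas compound 4 shows a change that moves away from measured numbers. In this assay, ((morpholin-4-yl)carbonyl)methyl gives an at least 2.8-fold higher number from compound 3 to compound 4 (0.44 log units; beyond the scatter), and the same group gives an at least 4.6-fold higher number from compound 2 to compound 4 (0.67 log units; beyond the scatter), so it reads as a weaker inhibitor than either compound with a real number, and the position is sensitive to which group it carries. Both steps give only a minimum size, and the step between compound 1 and compound 4 cannot be read, because of the assay's upper limit: the limit of >= 600000 nM in this assay, at which 2 of the 4 values shown sit.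

Compound 1 and compound 4 both carry a carbonyl on the saturated chain carbon bound to the oxygen, but two compounds cannot show whether that carbonyl, the anilino or the morpholin-4-yl decides the outcome. From the compounds shown here alone, it also remains open how a piperazine in place of morpholin-4-yl, a carboxylic acid, or a longer chain between the oxygen and the morpholine ring would read in this assay.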